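A few compounds are considered here, and "the series" means these few. Any claim that something is new, unique, unknown or untested is made for them only; others in the source may bear on it.

Of the compounds shown here, three that share a large common part have been tested. Compound 1 `Cc1ccc2nc(C(=O)Nc3c(F)cc(-c4cccc(F)c4)cc3F)c(C)c(O)c2c1`, compound 2 `CCc1ccc2nc(C(=O)Nc3c(F)cc(-c4cccc(F)c4)cc3F)c(C)c(O)c2c1` and compound 3 `CCOc1ccc2nc(C(=O)Nc3c(F)cc(-c4cccc(F)c4)cc3F)c(C)c(C(=O)O)c2c1` were each measured in a functional assay on A-375 cells (Homo sapiens) for antiproliferative activity, read by MTT assay, with a stated time of 24 h, tested at 0.05 ug/mL; on this read-out lower numbers stand for a weaker effect and higher numbers for a stronger effect at the one concentration tested. In this assay compound 1 gives 0.96%, compound 2 gives 0.68%, and compound 3 gives 1.96%. The change hydrogen in place of methyl on a saturated chain carbon bound to an aromatic carbon makes a step of a number 0.3 percentage points higher from compound 2 to compound 1 (within the scatter). The difference between the core of compound 2 and the core of compound 3 is not broken down here. Compound 4 `COc1ccc2nc(C(=O)Nc3c(F)cc(-c4cccc(F)c4)cc3F)c(C)c(C(=O)O)c2c1` has not yet been measured in this assay; it differs from compound 3 by hydrogen in place of methyl on a saturated chain carbon bound to an oxygen on an aromatic ring. Within the data shown here, this is the same kind of change as the one seen between compound 2 and compound 1, but not the same: there the place was on a saturated chain carbon bound to an aromatic carbon, here it is on a saturated chain carbon bound to an oxygen on an aromatic ring. Because the earlier step was a number 0.3 percentage points higher from compound 2 to compound 1 (within the scatter) and all three measured numbers sit close together, the expected step is a number 0.5 percentage points lower from compound 3 to compound 4 (within the scatter). Compound 4 is therefore estimated at 1.5%, expected to lie between 0% and 5%.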

Compound 4, a percentage reported as inhibition, at one concentration (the size of the read-out at that concentration, not a potency): 1.05%
Estimate against measurement, compound 4: 0.5 percentage points above, within the range that was stated.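

In this assay, going from ethoxy to methoxy gives a step that is a number 0.9 percentage points lower from compound 3 to compound 4 (within the scatter). Set beside the earlier change from ethyl to methyl, on a saturated chain carbon bound to an aromatic carbon rather than to an oxygen on an aromatic ring, the two steps cannot be told apart: the same change on two cores in this assay, a number 0.3 percentage points higher (within the scatter) from compound 2 to compound 1 and a number 0.9 percentage points lower (within the scatter) from compound 3 to compound 4, 1.2 percentage points apart, within the scatter of two such steps This shows that swapping methyl for hydrogen at these two places gives no step beyond the usual scatter on either core, but it does not show that the change is truly without effect or that it would behave the same way on another core, since every reading here is small and comes from one concentration.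

The compounds shown leave open whether a larger change at this place, such as a longer chain or an amine, would give a step beyond the scatter. They also leave open how this change would read on a core where the effect is large enough for a step to stand out.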